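The compounds below may be only part of what the source reports. "The series", "measured", "known", "first", "only" and "open" are said of these compounds alone.

Measured in a functional assay on HeLa cells (Homo sapiens) for inhibition, read by CCK-8 assay, with a stated time of 48 h; a higher number here means a weaker inhibitor, a lower number a stronger inhibitor:
Compound 1 `O=S(=O)(NCCNC(=S)Nc1cccc(Cl)c1)c1ccc(-c2ccccc2OCc2cccc(O)c2)s1` gives 10700 nM.
Compound 3 `O=[N+]([O-])c1ccc(Oc2ccccc2-c2ccc(S(=O)(=O)NCCNC(=S)Nc3cccc(Cl)c3)s2)cc1` gives 4600 nM.
Compound 2 `COc1ccc(NC(=O)NCCNS(=O)(=O)c2ccc(-c3ccccc3Oc3ccc([N+](=O)[O-])cc3)s2)cc1` gives > 20000 nM, which is a limit of the assay and not a number (the limit of > 20000 nM in this assay, at which 1 of the 3 values shown sits).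

Compound 4 `COc1ccc(NC(=O)NCCNS(=O)(=O)c2ccc(-c3ccccc3OCc3cccc(O)c3)s2)cc1` is not yet measured. Compounds 1 and 3 share one core; compounds 2 and 4 share another, which differs from it by a group of 11 heavy atoms (8 carbon, 1 nitrogen, 2 oxygen; one six-membered aromatic ring of carbon only) in place of a group of 10 heavy atoms (7 carbon, 1 nitrogen, 1 sulfur, 1 chlorine; one six-membered aromatic ring of carbon only), on an amine nitrogen. In this assay that core difference shows as an at least 4.3-fold lower number from compound 2 to compound 3 (0.63 log units; beyond the scatter).

The change from compound 3 to compound 1 is 3-hydroxybenzyl in place of 4-nitrophenyl on an oxygen on an aromatic ring; it gave a 2.3-fold higher number from compound 3 to compound 1 (0.37 log units; beyond the scatter). The same change, (3-hydroxybenzyl in place of 4-nitrophenyl on an oxygen on an aromatic ring), at the same place, is made from compound 2 to compound 4, so it occurs twice among these compounds.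

For compound 4 the expected step is a step that the limit leaves unreadable from compound 2 to compound 4, resting on a 2.3-fold higher number from compound 3 to compound 1 (0.37 log units; beyond the scatter) applied to a value that is already a limit. Compound 4 is therefore expected to give about 45000 nM, most likely reported again only as a limit, within 20000 nM to 120000 nM.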

Compound 4, half-maximal inhibitory concentration: > 20000 nM
Compound 4: a limit, no number; the forecaster's own chance of this, stated with the estimate: 85%; the middle value lies beyond the limit too.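

In this assay compound 4 gives > 20000 nM, which is a limit of the assay and not a number. The swap of 4-nitrophenyl for 3-hydroxybenzyl therefore cannot be read on this core, and whether it carries over from the other core stays unknown, since both ends of the step sit at the limit: the limit of > 20000 nM in this assay, at which 2 of the 4 values shown sit.

Changing the group on the amine nitrogen, with 3-hydroxybenzyl in place, gives an at least 1.8-fold higher number from compound 1 to compound 4 (0.27 log units; that floor lies within the scatter), and whether this matches the pair carrying 4-nitrophenyl stays unsettled: the same change on two cores in this assay, an at least 4.3-fold lower number (0.63 log units; beyond the scatter) from compound 2 to compound 3 and an at least 1.8-fold lower number (0.27 log units; that floor lies within the scatter) from compound 4 to compound 1; the limit leaves it open whether they differ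

The compounds shown leave open whether any group on this oxygen gives the core of compound 2 a readable number. On these data alone, an aminobenzyl group or a benzyl group bearing a carboxylic acid in place of 3-hydroxybenzyl remains untested among them.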